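A few compounds are considered here, and "the series" means these few. Any claim that something is new, unique, unknown or untested is made for them only; others in the source may bear on it.

The three measured compounds share a core and differ at the amide end and along the ring system. Compound 1, `CCOc1ccc2nc(C(F)(F)F)cc(OCC(=O)Nc3cc(C)cc(C)c3)c2c1`, is reported in a physicochemical assay for solubility, in phosphate buffer, measured as kinetic solubility, with a stated time of 1 h, at pH 7.4 (on this read-out lower numbers stand for lower solubility and higher numbers for higher solubility), only as a limit of the assay, < 1000 nM, and not as a number; this is the case noted in the limit of < 1000 nM in this assay, at which 1 of the 3 values shown sits. Compound 2, `COc1ccc2nc(C)cc(OCC(=O)Nc3cc(C)ccc3OC)c2c1`, gives 9500 nM in this assay, which is the lowest of the two numbers measured. Compound 3, `COc1ccc2nc(C)cc(OCC(=O)Nc3cc(OC)c(OC)c(OC)c3)c2c1`, gives 34000 nM in this assay, a higher number than compound 2 by more than the scatter. Going by the values given here, because compound 1, compound 2 and compound 3 each differ in more than one place, no single step between measured compounds is available, and what follows rests on the structures alone.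

Compound 4, `COc1ccc2nc(C)cc(OCC(=O)Nc3nccs3)c2c1`, is not yet measured in this assay. It differs from compound 2 by 1,3-thiazol-2-yl in place of 2-methoxy-5-methylphenyl on an amide-type nitrogen. The move from a six-membered aromatic ring of carbon only, carrying two substituents, to a five-membered aromatic ring with two heteroatoms is expected to raise the solubility number, with the step from compound 2 to compound 4 estimated as a 3.2-fold higher number from compound 2 to compound 4 (0.50 log units; beyond the scatter), beyond the scatter. Compound 4 is therefore expected to give about 30000 nM in this assay, within a range from 9000 nM to 100000 nM.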

Compound 4, solubility: 54000 nM
Compound 4: the middle estimate sits 1.8-fold (0.26 log units) below what was measured; low and high end bracket the measured number.
By their numbers in this assay, from the lowest: compound 2; then compounds 3 and 4 (each within the scatter of the next). At a limit, below all of these: compound 1.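

In this assay, this is the first step shown that changes a single place, and it puts the amide-type nitrogen on record as a position where the read-out moves: 1,3-thiazol-2-yl in place of 2-methoxy-5-methylphenyl gives a 5.7-fold higher number from compound 2 to compound 4 (0.75 log units; beyond the scatter). The earlier compounds shown here differ from one another in more than one place, so they could tie no difference to this position or to any other, whereas this pair holds the rest of the structure fixed and leaves only the group on that nitrogen to change. Even so, nothing measured here bears on why the number moves with this change, and the step rests on one pair of compounds.

Going by these compounds, the step changes ring size, ring atoms and substituents all at once, so it remains open which of these goes with the higher number. On these data alone, a plain phenyl, a pyridin-2-yl or a 1,3-thiazol-2-yl carrying a methyl group on the same amide-type nitrogen, with the rest of compound 2 unchanged, would begin to separate them, and whether the step carries over to other substituents on the shared core also remains open.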